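Compound 3 to compound 4: methyl in place of methoxy

The source may hold more compounds than are shown below. What is called first, only, known or untested is meant among the compounds shown, and "the series" means these compounds.

In an ADME assay on microsomes from liver (Mus musculus) for metabolic stability, read by HPLC, with a stated time of 30 min (a lower number here means that less of the compound is left, a higher number that more of the compound is left), compound 1 (`Cc1ccc(NC(=O)C(=O)c2c[nH]c3cc(C)ccc23)cc1`) gives 90.2% and compound 2 (`Cc1ccc(NC(=O)C(=O)c2c[nH]c3cc(Cl)ccc23)cc1`) gives 85.6%. Compound 3 (`COc1ccc(NC(=O)C(=O)c2c[nH]c3cc(C(C)C)ccc23)cc1`) gives 86.2%, within the scatter of both. Compound 4 (`Cc1ccc(NC(=O)C(=O)c2c[nH]c3cc(C(C)C)ccc23)cc1`) has not yet been measured. It carries methyl in place of methoxy on an aromatic carbon, para to a large group: methyl in place of methoxy on an aromatic carbon. For the measured compounds named here, no measured step makes this exchange. Going by the values given here, the only measured step, a number 4.6 percentage points lower from compound 1 to compound 2 (within the scatter), is a different exchange, chloro in place of methyl on an aromatic carbon, and it offers only indirect guidance. Compound 1 and compound 2 already carry the 4-methylphenyl group, and their values stay within the scatter of compound 3. No step beyond the scatter is therefore expected in this assay. The estimated step is a number 0.8 percentage points higher from compound 3 to compound 4 (within the scatter), which would lie within the scatter. Compound 4 is estimated at 87%, with an expected range from 78% to 95%.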

Compound 4, percent of the compound remaining: 82.6%
Compound 4: middle estimate off by 4.4 percentage points, on the high side; measured number inside the range.
By their numbers in this assay, from the lowest: compounds 4, 2, 3 and 1 (each within the scatter of the next).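

In this assay, for the compounds shown here, the change from 4-methoxyphenyl to 4-methylphenyl, para to a large group, gives a number 3.6 percentage points lower from compound 3 to compound 4 (within the scatter) as the first direct reading of this exchange, so with isopropyl held on the core the two groups cannot be told apart. With 4-methylphenyl held, the other substituent on the core also makes no clear difference: the change to isopropyl gives a number 3 percentage points lower from compound 2 to compound 4 (within the scatter) from chloro and a number 7.6 percentage points lower from compound 1 to compound 4 (within the scatter) from methyl. Nothing available bears on why the four numbers lie where they do.

Going by these compounds, whether a larger change at this place, such as an amine, a carboxylic acid or a longer chain, would give a step beyond the scatter remains open. The compounds shown also leave open whether the two places act independently, since no step here rises above the scatter.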